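Trifluoromethoxy for Trifluoromethyl in Two Related Cores

The compounds below may be only part of what the source reports. "The series", "measured", "known", "first", "only" and "open" are said of these compounds alone.

Compound 1 `CC(O)(CSc1ccccc1C(F)(F)F)C(=O)Nc1ccc(S(F)(F)(F)(F)F)cc1` and compound 2 `CC(O)(CSc1ccccc1OC(F)(F)F)C(=O)Nc1ccc(S(F)(F)(F)(F)F)cc1` share one core; compound 3 `CC(O)(CSc1ccc(C(F)(F)F)cc1)C(=O)Nc1cccc(S(F)(F)(F)(F)F)c1` and compound 4 `CC(O)(CSc1ccc(OC(F)(F)F)cc1)C(=O)Nc1cccc(S(F)(F)(F)(F)F)c1` share another, built from the same atoms joined differently, and the difference between the two cores is not broken down here. In a functional assay on LNCaP cells (Homo sapiens) for antiproliferative activity, read by propidium iodide staining, with a stated time of 96 h (a higher number here means a weaker inhibitor, a lower number a stronger inhibitor), compound 1 gives 12300 nM, compound 2 gives 10600 nM, and compound 3 gives 17500 nM. Within the first core the change is trifluoromethoxy in place of trifluoromethyl on an aromatic carbon, and in this assay it made a step of a 1.2-fold lower number from compound 1 to compound 2 (0.06 log units; within the scatter). Within the second core the change is trifluoromethoxy in place of trifluoromethyl on an aromatic carbon. It is the same kind of change but not the same: in the first pair the group sits ortho to a large group, in the second para to a large group. Compound 4 has not yet been measured in this assay. Because the earlier step of a 1.2-fold lower number from compound 1 to compound 2 (0.06 log units; within the scatter) stayed within the scatter, a step of a 1.2-fold lower number from compound 3 to compound 4 (0.07 log units; within the scatter) is expected here. Compound 4 is therefore estimated at 15000 nM in this assay, with a likely range from 7000 nM to 35000 nM.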

Compound 4, half-maximal inhibitory concentration: 10300 nM
Estimate against measurement, compound 4: 1.5-fold (0.16 log units) above, and the stated range covers the measured number.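

In this assay, trifluoromethoxy in place of trifluoromethyl on the second core gave a 1.7-fold lower number from compound 3 to compound 4 (0.23 log units; within the scatter), so this step is too small to count as a real change. Set beside the step on the first core, it suggests that the swap behaves alike on these two cores, with neither step nor the gap between them standing out from ordinary measurement noise: the same change on two cores in this assay, a 1.2-fold lower number (0.06 log units; within the scatter) from compound 1 to compound 2 and a 1.7-fold lower number (0.23 log units; within the scatter) from compound 3 to compound 4, 1.5-fold (0.17 log units) apart, within the scatter of two such steps. Going by these compounds alone, this shows only that the two pairs agree in giving no clear effect; it does not show that trifluoromethoxy improves on trifluoromethyl, and two pairs cannot establish that the same would hold on any further core.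

The compounds shown carry only trifluoromethyl or trifluoromethoxy on this ring, so it remains open whether a different group there, such as a nitrile, an amine or a carboxylic acid, would move the number clearly beyond the scatter. On these data alone, how the two cores themselves compare also remains open, as they differ in more than one place.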